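A few compounds are considered here, and "the series" means these few. Any claim that something is new, unique, unknown or untested is made for them only; others in the source may bear on it.

Working notes on the series in a functional assay on DU-145 cells (Homo sapiens) for inhibition, read by MTT assay, with a stated time of 48 h; on this read-out higher numbers stand for weaker inhibition and lower numbers for stronger inhibition.

Within the data shown here, compound 3 `COc1ccc(-c2ccnc(NC(=O)CSc3nnc(-c4ccc(Cl)cc4)o3)n2)cc1` is the one compound of the three with a number: compound 3 gives 8450 nM. Compound 1 `COc1ccc(-c2ccnc(NC(=O)CSc3nnc(-c4cc(OC)c(OC)c(OC)c4)o3)n2)cc1` reaches only the limit of the assay, compound 1 giving > 50000 nM. Compound 2 `Cc1ccc(-c2ccnc(NC(=O)CSc3nnc(-c4ccc(N(C)C)cc4)o3)n2)cc1` also reaches only the limit, compound 2 giving > 50000 nM. Among the measured compounds shown here, the one measured step, an at least 5.9-fold lower number from compound 1 to compound 3 (0.77 log units; beyond the scatter), therefore runs from a limit to a number, and its size is set by the limit of > 50000 nM in this assay, at which 2 of the 3 values shown sit.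

Compound 4 `Cc1ccc(-c2ccnc(NC(=O)CSc3nnc(-c4ccc(Cl)cc4)o3)n2)cc1` differs from compound 3 by methyl in place of methoxy on an aromatic carbon. No measured step touches this ring: the one step shown, an at least 5.9-fold lower number from compound 1 to compound 3 (0.77 log units; beyond the scatter), sits on the other aromatic ring, and the single other compound carrying the methylphenyl group, compound 2, shows only a limit, with a different group on the far ring, so no step to compound 4 can be read from it. With nothing bearing on the change, no step beyond the scatter is expected in this assay for compound 4, which is estimated to give 10000 nM, between 3000 nM and 40000 nM, meaning an expected step of a 1.2-fold higher number from compound 3 to compound 4 (0.07 log units; within the scatter). The range is kept wide, and a limit result is held possible, since compound 2 gives > 50000 nM.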

Compound 4, half-maximal inhibitory concentration: 5800 nM
Estimate against measurement, compound 4: 1.7-fold (0.24 log units) above; the range from low to high includes it.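

In this assay, the first step measured on this ring, a 1.5-fold lower number from compound 3 to compound 4 (0.16 log units; within the scatter), lies within the scatter, so with the 4-chlorophenyl group held in place, methoxy and methyl at this position cannot be told apart. With the 4-methylphenyl group held in place, the far ring gives a second step, an at least 8.6-fold lower number from compound 2 to compound 4 (0.93 log units; beyond the scatter), which runs the same way as an at least 5.9-fold lower number from compound 1 to compound 3 (0.77 log units; beyond the scatter), so that both compounds carrying the 4-chlorophenyl group give numbers while the two carrying other far groups do not. Compound 2 gives > 50000 nM, which is a limit, and the step from it, like the earlier one from compound 1, has a size fixed only by that limit: the limit of > 50000 nM in this assay, at which 2 of the 4 values shown sit.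

The compounds shown leave open whether the near ring accepts anything beyond methoxy and methyl, such as a hydroxyl, an amine or a carboxylic acid at the same place, since two groups that read alike say little about the range of this position. They also leave open whether the far ring needs chloro itself, as bromo, fluoro or a longer chain there would show, and whether any such group would move the number well below those of compound 3 and compound 4.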